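Selenocyanate carbamates: halogen swap on the phenyl carbamate

The source may hold more compounds than are shown below. What is called first, only, known or untested is meant among the compounds shown, and "the series" means these compounds.

Measured so far:
compound 1 `COc1ccc(OC(=O)Nc2ccc([Se]C#N)cc2)cc1`, 41500 nM
compound 2 `O=C(Nc1ccc([Se][Se]c2ccc(NC(=O)OCc3ccccc3)cc2)cc1)OCc1ccccc1`, 35400 nM
compound 3 `N#C[Se]c1ccc(NC(=O)Oc2ccc(F)cc2)cc1`, 37600 nM

In a functional assay on HT-29 cells (Homo sapiens) for cytotoxicity, read by MTT assay, with a stated time of 72 h (a lower number here means a stronger inhibitor of growth, a higher number a weaker inhibitor of growth), compound 3 gives 37600 nM, the second highest of the three numbers; compound 2 and compound 1 lie within the scatter of it on either side. Within the data shown here, the only one-place step known, a 1.1-fold lower number from compound 1 to compound 3 (0.04 log units; within the scatter), changed a substituent on the same aromatic carbon and stayed within the scatter.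

Compound 4 `N#C[Se]c1ccc(NC(=O)Oc2ccc(Cl)cc2)cc1` carries chloro in place of fluoro on an aromatic carbon, the change sitting para to a large group. Among the measured compounds shown here, the single step that bears on it was flat, and chloro for fluoro is a move of the same kind, so no shift beyond the scatter is expected: the step from compound 3 to compound 4 is estimated as a 1.0-fold lower number from compound 3 to compound 4 (0.02 log units; within the scatter). Compound 4 is thus expected to give about 36000 nM, within 18000 nM to 72000 nM.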

Compound 4, concentration for total growth inhibition: 40300 nM
Estimate against measurement, compound 4: 1.1-fold (0.05 log units) below; measured number inside the range.
By their numbers in this assay, from the lowest: compounds 2, 3, 4 and 1 (each within the scatter of the next).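

In this assay chloro on this aromatic carbon, para to a large group, behaves like the earlier substituents: a 1.1-fold higher number from compound 3 to compound 4 (0.03 log units; within the scatter) and a 1.0-fold lower number from compound 1 to compound 4 (0.01 log units; within the scatter). Methoxy, fluoro and chloro at this position thus all lie within the scatter of one another, so swapping one halogen for the other leaves the read-out as flat as replacing methoxy did. No measurement here speaks to the reason for this flatness.

Open, going by these compounds, is whether an amine or a carboxylic acid on this carbon would move the number beyond the scatter. Also open, on these data alone, is whether a longer chain here would do so.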